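The compounds below may be only part of what the source reports. "The series", "measured", "known", "first", "only" and "open" are said of these compounds alone.

In a functional assay on LNCaP cells (Homo sapiens) for cytotoxicity, read by MTT assay (on this read-out higher numbers stand for weaker inhibition and lower numbers for stronger inhibition), compound 1 `COc1ccc2cc([C@H](C)c3nnc(SCc4c(C)cc(C)cc4C)n3-c3cccc(Cl)c3)ccc2c1` gives <= 400000 nM, and this is a limit, not a number.

Two other compounds in the series do give numbers. Compound 2 `COc1ccc2cc([C@H](C)c3nnc(SCc4ccc(Cl)cc4)n3-c3ccc(Cl)cc3)ccc2c1` reads 110000 nM and compound 3 `COc1ccc2cc([C@H](C)c3nnc(SCc4c(Cl)cccc4Cl)n3-c3cccc(Cl)c3)ccc2c1` reads 73700 nM, and these two values lie within the usual scatter of each other.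

Compound 4 `COc1ccc2cc([C@H](C)c3nnc(SCc4c(C)cc(C)cc4C)n3-c3ccc(F)cc3)ccc2c1` keeps the rest of compound 1 but carries 4-fluorophenyl in place of 3-chlorophenyl on an aromatic nitrogen. The swap keeps the ring and changes only the halogen and where it sits on that ring.

Within the data shown here, the one measured step that starts from the same compound is a step that the limit leaves unreadable from compound 1 to compound 3. It changes a different part of the molecule, and its size cannot be read, so it offers no size to carry over. Among the measured compounds shown here, no measured step isolates the group on the nitrogen either.

With so little to go on, no shift beyond the scatter is expected in this assay, and no direction can be argued. The estimate therefore stays between the limit and the two measured numbers.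

Compound 4 is expected at about 220000 nM, with an estimated range from 70000 nM to 400000 nM.

Read against a limit, the expected change is a step that the limit leaves unreadable from compound 1 to compound 4.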

Compound 4, half-maximal inhibitory concentration: 2210 nM
For compound 4 the middle estimate is 100-fold (2.00 log units) above the measured one; the whole stated range lies above it.
By their numbers in this assay, from the lowest: compound 4; then compounds 3 and 2 (each within the scatter of the next).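

The step from compound 1 to compound 4 cannot be read, because compound 1 has only a limit and not a number: the limit of <= 400000 nM in this assay, at which 1 of the 4 values shown sits. The compounds shown leave open how far 4-fluorophenyl in place of 3-chlorophenyl on an aromatic nitrogen shifts the value on its own, with no pair of two readable numbers differing only there.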